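The source may hold more compounds than are shown below. What is called first, only, known or untested is meant among the compounds shown, and "the series" means these compounds.

Measured so far:
Compound 1, `Cn1c(=O)c(S(=O)(=O)c2ccc(F)cc2[N+](=O)[O-])cc2cnc(Nc3ccc4[nH]ccc4c3)nc21`, gives 1500 nM.
Compound 2, `O=c1[nH]c2nc(Nc3ccc4[nH]ccc4c3)ncc2cc1S(=O)(=O)c1ccc(F)cc1F`, gives 15000 nM.
Compound 3, `Cc1ccc(S(=O)(=O)c2cc3cnc(Nc4ccc5ncccc5c4)nc3n(C)c2=O)cc1`, gives 10000 nM.

All three were tested in a functional assay on DU-145 cells (Homo sapiens) for inhibition, read by trypan blue exclusion, with a stated time of 72 h; on this read-out lower numbers stand for stronger inhibition and higher numbers for weaker inhibition. Among these three numbers compound 1 stands lowest, and its gaps to compound 3 and to compound 2 are both larger than the usual scatter of repeated measurements, so within this small set compound 1 is the most potent inhibitor. Compound 2 and compound 3 sit close to one another, and the data show no change between them that should be trusted.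

The next compound to consider is compound 4, `Cn1c(=O)c(S(=O)(=O)c2ccc(Br)cc2)cc2cnc(Nc3ccc4[nH]ccc4c3)nc21`, which has not yet been measured in this assay. It differs from compound 1 in one place: 4-bromophenyl in place of 4-fluoro-2-nitrophenyl on a sulfonyl sulfur. Everything else in the shared core stays the same. For the measured compounds named here, no pair of measured compounds that differ in exactly one place is available, so the effect of swapping the group on the sulfonyl sulfur cannot be read off directly. Compound 2 and compound 3 both carry other groups on that sulfur, but they also differ from compound 1 elsewhere, so their values only hint that changes around the sulfone can be costly. On that basis the step from compound 1 to compound 4 is expected to lose some potency, by a 2.3-fold higher number from compound 1 to compound 4 (0.37 log units; beyond the scatter), a step that may or may not exceed the scatter. Compound 4 is therefore estimated at 3500 nM, with a plausible range from 1000 nM to 12000 nM.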

Compound 4, half-maximal inhibitory concentration: 5000 nM
Estimate against measurement, compound 4: 1.4-fold (0.15 log units) below; low and high end bracket the measured number.
By their numbers in this assay, from the lowest: compound 1; then compounds 4, 3 and 2 (each within the scatter of the next, the first and the last beyond it).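

In this assay, for the compounds shown here, replacing 4-fluoro-2-nitrophenyl with 4-bromophenyl on a sulfonyl sulfur gives a 3.3-fold higher number from compound 1 to compound 4 (0.52 log units; beyond the scatter), and this is the first comparison here in which nothing else in the compound changes. The earlier compounds shown here also differed elsewhere, so they could only hint at the importance of this position, whereas this modest step ties a loss of potency to the group on the sulfonyl sulfur alone. The result shows that this position affects the read-out, but nothing shown explains why this change has that effect.

The swap alters several features at once: the nitro group leaves, the fluorine is lost and a bromine enters, so the compounds shown leave open which of these accounts for the step. Also open, as far as these compounds go, is how the read-out would respond to other groups on the ring attached to the sulfonyl sulfur, such as an amine or a carboxylic acid, and whether a nitro group alone, without the fluorine, would give a value like that of compound 1.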